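Aryl substituent on the triazinedione nitrogen: 2,6-dichlorophenyl analogue

The source may report more compounds than this note shows. Statements on the series, on what has been measured and on what is new or still open speak of the compounds shown alone.

Measured compounds, all read in a functional assay on MKN-45 cells (Homo sapiens) for cytotoxicity, read by MTT assay, with a stated time of 72 h; a lower number here means a stronger inhibitor, a higher number a weaker inhibitor:
- compound 1 `Cn1c(=O)c(C(=O)Nc2ccc(Oc3ccncc3-c3cccnc3)c(F)c2)nn(-c2ccccc2F)c1=O` gives 4780 nM
- compound 2 `Cn1c(=O)c(C(=O)Nc2ccc(Oc3ccncc3-c3cccnc3)c(F)c2)nn(-c2ccc(Cl)cc2)c1=O` gives 1600 nM
- compound 3 `Cn1c(=O)c(C(=O)Nc2ccc(Oc3ccncc3-c3cccnc3)c(F)c2)nn(-c2cccc(C(F)(F)F)c2)c1=O` gives 1950 nM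

Compound 3 stands second highest of the three numbers; its nearest neighbour is compound 2, within the scatter, and its furthest is compound 1, beyond it. The next compound, compound 4 `Cn1c(=O)c(C(=O)Nc2ccc(Oc3ccncc3-c3cccnc3)c(F)c2)nn(-c2c(Cl)cccc2Cl)c1=O`, differs from compound 3 only in the change (2,6-dichlorophenyl in place of 3-(trifluoromethyl)phenyl on an aromatic nitrogen). For the measured compounds named here, no measured step replaces one aryl group by another of this kind, so the bearing is indirect: a 3.0-fold lower number from compound 1 to compound 2 (0.48 log units; beyond the scatter) and a 2.5-fold lower number from compound 1 to compound 3 (0.39 log units; beyond the scatter) both leave the 2-fluorophenyl compound 1 as the weakest, while a 1.2-fold higher number from compound 2 to compound 3 (0.09 log units; within the scatter) is flat. A modest rise in the number is therefore expected, a 2.1-fold higher number from compound 3 to compound 4 (0.31 log units; beyond the scatter), with wide uncertainty. For compound 4 the estimate in this assay is 4000 nM, range 1500 nM to 12000 nM.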

Compound 4, half-maximal inhibitory concentration: 3930 nM
Compound 4: middle estimate off by 1.0-fold (0.01 log units), on the high side, and the stated range covers the measured number.
By their numbers in this assay, from the lowest: compounds 2, 3, 4 and 1 (each within the scatter of the next, the first and the last beyond it).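

In this assay, only a 2.5-fold higher number from compound 2 to compound 4 (0.39 log units; beyond the scatter) lies beyond the scatter, whereas a 2.0-fold higher number from compound 3 to compound 4 (0.30 log units; within the scatter) and a 1.2-fold lower number from compound 1 to compound 4 (0.09 log units; within the scatter) do not. The 2,6-dichlorophenyl group thus matches the 2-fluorophenyl group of compound 1 at this nitrogen and separates from the 4-chlorophenyl group of compound 2, though compound 3 blurs this split by lying within the scatter of both compound 2 and compound 4. No supporting measurement accounts for these differences.

Going by these compounds, whether this nitrogen needs an aryl group at all remains open. A benzyl group, a pyridyl ring or a phenyl ring carrying an amine or a carboxylic acid would test this.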